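The source may hold more compounds than are shown below. What is called first, only, known or untested is meant among the compounds shown, and "the series" means these compounds.

Of the compounds shown here, three have been measured in an ADME assay on cells (Homo sapiens) for cytotoxicity, read by polymerase chain reaction, with a stated time of 3 days; a lower number here means that less compound is tolerated, a higher number that more compound is tolerated. Compound 1 `Cc1nc(NCC2CCC2)nc(N[C@@H]2C[C@H](CO)[C@@H](O)[C@H]2O)c1-c1nc2ccccc2s1` gives > 25000 nM, which is a limit of the assay and not a number. Compound 2 `Cc1nc(NCCNC(=O)NC(C)(C)C)nc(N[C@@H]2C[C@H](CO)[C@@H](O)[C@H]2O)c1-c1nc2ccccc2s1` gives > 25000 nM, again a limit. Within the data shown here, compound 3 `Cc1nc(NCCC(F)(F)F)nc(N[C@@H]2C[C@H](CO)[C@@H](O)[C@H]2O)c1-c1nc2ccccc2s1` gives 9000 nM, the only number among the three values shown; the other two sit at the limit of > 25000 nM in this assay, at which 2 of the 3 values shown sit. The step from compound 1 to compound 2 is a step that the two limits leave unreadable from compound 1 to compound 2. Among the measured compounds shown here, two steps lead to the single number, an at least 2.7-fold lower number from compound 1 to compound 3 (0.44 log units; beyond the scatter) and an at least 2.7-fold lower number from compound 2 to compound 3 (0.44 log units; beyond the scatter), both changes on a saturated chain carbon bound to a nitrogen on an aromatic ring.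

Compound 4 `Cc1nc(NCc2cccnc2)nc(N[C@@H]2C[C@H](CO)[C@@H](O)[C@H]2O)c1-c1nc2ccccc2s1` differs from compound 3 in pyridin-3-yl in place of 2,2,2-trifluoroethyl on a saturated chain carbon bound to a nitrogen on an aromatic ring. For the measured compounds named here, both measured steps that touch this place run from a limit down to the one number, so with the 2,2,2-trifluoroethyl group gone the value for compound 4 is expected to move back toward the limit; the expected step is a 2.2-fold higher number from compound 3 to compound 4 (0.35 log units; beyond the scatter). Compound 4 is estimated at 20000 nM, within 7000 nM to 25000 nM, with a real chance that only a limit is reported.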

Compound 4, half-maximal cytotoxic concentration: 5000 nM
Estimate against measurement, compound 4: 4.0-fold (0.60 log units) above, outside the stated range (below it).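

In this assay, a second group at this place, on a saturated chain carbon bound to a nitrogen on an aromatic ring, now gives a number and not a limit, and the change is a 1.8-fold lower number from compound 3 to compound 4 (0.26 log units; within the scatter), so pyridin-3-yl and 2,2,2-trifluoroethyl are not told apart here. Against the two compounds held at a limit, the steps are an at least 5.0-fold lower number from compound 2 to compound 4 (0.69 log units; beyond the scatter) and an at least 5.0-fold lower number from compound 1 to compound 4 (0.69 log units; beyond the scatter), so leaving the limit at this place is no longer tied to a group carrying fluorine. Compound 1 and compound 2 remain limits of the assay and not numbers: the limit of > 25000 nM in this assay, at which 2 of the 4 values shown sit.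

On these data alone, how far compound 1 and compound 2 truly lie from compound 4 stays open. Also open, as far as these compounds go, is whether phenyl, or a longer chain ending in an amine or a carboxylic acid, would give a number at this place or return to the limit.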